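Removing a Trifluoromethyl Group From a Weakly Cytotoxic Amide

A few compounds are considered here, and "the series" means these few. Any claim that something is new, unique, unknown or untested is made for them only; others in the source may bear on it.

Compound 1, `COc1cc(-c2nn(-c3cccc(NC(=O)c4cccc(C(F)(F)F)c4)c3)cc2-c2ccncc2)ccc1Cl`, was tested in a functional assay on IGROV-1 cells (Homo sapiens) for inhibition, read by sulforhodamine B assay, with a stated time of 48 h; a lower number here means that less compound is tolerated, a higher number that more compound is tolerated. In this assay compound 1 gives only a limit, > 50000 nM, meaning that no number could be fixed at the highest concentration tested. Compound 2, `O=C(Nc1cccc(-n2cc(-c3ccncc3)c(-c3ccc(Cl)c(O)c3)n2)c1)Nc1cc(C(F)(F)F)cc(C(F)(F)F)c1`, belongs to the same set, and in this assay compound 2 gives 38200 nM. Compound 1 therefore stands at the edge of what this assay can record, as shown by the limit of > 50000 nM in this assay, at which 1 of the 2 values shown sits.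

Compound 3, `COc1cc(-c2nn(-c3cccc(NC(=O)c4ccccc4)c3)cc2-c2ccncc2)ccc1Cl`, has not yet been measured. It differs from compound 1 in one place: hydrogen in place of trifluoromethyl on an aromatic carbon, so hydrogen stands in place of trifluoromethyl on an aromatic carbon. Among the compounds with values here, no measured pair shows this same change, so the size of the step is open. The expected step of a number no higher from compound 1 to compound 3 (the limit leaves the size open) is estimated to stay within the usual scatter. Compound 3 is expected to give about 50000 nM, between 20000 nM and 100000 nM, quite possibly again reported only as a limit.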

Compound 3, concentration lethal to 50% of the cells: > 100000 nM
Compound 3: only a limit was reported; the forecaster's own chance of this, stated with the estimate: 60%; middle value at least 2.0-fold (0.30 log units) away from the limit.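

In this assay compound 3 gives > 100000 nM as a limit. Compound 1 gives > 50000 nM as a limit too. With only these two limits, no step can be read between compound 1 and compound 3. From the compounds shown here alone, whether hydrogen in place of trifluoromethyl changes the lethal concentration at all stays open.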